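The source may hold more compounds than are shown below. What is called first, only, known or untested is meant among the compounds shown, and "the series" means these compounds.

Compound 1 `Cc1ccccc1OCc1cn(-c2ccc(S(=O)(=O)N3CCc4ccccc4C3)cc2)nn1` gives in an ADME assay on Vero cells (Chlorocebus sabaeus) for cytotoxicity, with a stated time of 4 days (a higher number here means a weaker inhibitor, a lower number a stronger inhibitor), only the limit > 50 ug/mL.
Compound 2 `COc1cc2c(cc1OC)CN(S(=O)(=O)c1ccc(-n3cc(COc4ccc([N+](=O)[O-])cc4)nn3)cc1)CC2` gives in this assay only the limit > 50 ug/mL.
Compound 3 `COc1cc2c(cc1OC)CN(S(=O)(=O)c1ccc(-n3cc(COc4ccc(C)cc4)nn3)cc1)CC2` gives in this assay only the limit > 50 ug/mL.

Compound 1 stands nowhere that can be ranked: its value in this assay is a limit, and the two further values shown are limits as well, so none of the three compounds can be placed above or below another. Among the compounds with values here, the one step between measured compounds that differ in a single place, a step that the two limits leave unreadable from compound 2 to compound 3, is a change of methyl in place of nitro on an aromatic carbon; with both ends at a limit its size cannot be read. The change from compound 1 to compound 4 `O=S(=O)(c1ccc(-n2cc(COc3ccc4ccccc4c3)nn2)cc1)N1CCc2ccccc2C1` is naphthalen-2-yl in place of 2-methylphenyl on an oxygen on a saturated carbon. Within the data shown here, no measured step touches this part of the structure, and the only evidence on the measured steps is the limit of > 50 ug/mL in this assay, at which 3 of the 3 values shown sit. Compound 4 is therefore expected to show a step that the limit leaves unreadable from compound 1 to compound 4 that does not carry it off the limit, with the same outcome in this assay as the three measured compounds. Compound 4 is estimated in this assay at 55 ug/mL, within 30 ug/mL to 120 ug/mL.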

Compound 4, half-maximal inhibitory concentration: > 50 ug/mL
Compound 4: no number, only a limit; the forecaster's own chance of this, stated with the estimate: 80%; the middle value does not contradict the limit.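

In this assay compound 4 gives only a limit, > 50 ug/mL. Compound 1 is also held at a limit, so no step can be read for naphthalen-2-yl in place of 2-methylphenyl. The compounds shown leave open where any of them truly lies relative to the others, since none has a value that can be ranked: the limit of > 50 ug/mL in this assay, at which 4 of the 4 values shown sit.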